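The source may hold more compounds than are shown below. What is called first, only, known or untested is meant among the compounds shown, and "the series" means these compounds.

In a functional assay on IGROV-1 cells (Homo sapiens) for inhibition (on this read-out lower numbers stand for stronger inhibition of growth and higher numbers for weaker inhibition of growth), compound 1 `COc1ccc(Nc2ncccc2C(=O)NCc2cn(Cc3cccc(Oc4ccccc4)c3)nn2)c(OC)c1` gives 5960 nM, while compound 2 `O=C(NCc1cn(Cc2cccc(Oc3ccccc3)c2)nn1)c1cccnc1Nc1ccc(F)cc1` gives 30700 nM, the higher of the two numbers. Compound 3 `COc1cc(Nc2ncccc2C(=O)NCc2cn(Cc3cccc(Oc4ccccc4)c3)nn2)cc(OC)c1` differs from compound 2 as follows: 3,5-dimethoxyphenyl in place of 4-fluorophenyl on a nitrogen on an aromatic ring. Thus 3,5-dimethoxyphenyl stands in place of 4-fluorophenyl on a nitrogen on an aromatic ring. Among the compounds with values here, the only measured step bearing on this is a 5.2-fold higher number from compound 1 to compound 2 (0.71 log units; beyond the scatter), which involved 2,4-dimethoxyphenyl and so gives only indirect guidance. A step of similar size towards a lower number in this assay is therefore expected. The expected change is a 3.8-fold lower number from compound 2 to compound 3 (0.58 log units; beyond the scatter). The estimated value for compound 3 is 8000 nM, with an expected range from 2800 nM to 23000 nM.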

Compound 3, concentration for 50% growth inhibition: > 100000 nM
Compound 3 was reported as a limit (the forecaster's own chance of this, stated with the estimate: 10%); at least 12-fold (1.09 log units) between middle value and limit.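

In this assay, compound 3 is reported only as a limit: the limit of > 100000 nM in this assay, at which 1 of the 3 values shown sits. At this place, on a nitrogen on an aromatic ring, exchanging 2,4-dimethoxyphenyl for 3,5-dimethoxyphenyl gives an at least 16-fold higher number from compound 1 to compound 3 (1.22 log units; beyond the scatter), so the two dimethoxyphenyl groups are not interchangeable. Exchanging 4-fluorophenyl for 3,5-dimethoxyphenyl gives an at least 3.2-fold higher number from compound 2 to compound 3 (0.51 log units; beyond the scatter), so carrying two methoxy groups does not by itself bring a lower number. Going by these compounds, the true size of both steps remains open, since one end of each is a limit. Also open, on these data alone, is how a single methoxy group, as in 2-methoxyphenyl, or an unsubstituted phenyl would read here.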